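This account rests on a few compounds, and the source may have more. Where it says the series, first, only, none or still open, it means among the compounds named here.

In an ADME assay on RD cells (Homo sapiens) for cytotoxicity, read by neutral red uptake, with a stated time of 3 days (on this read-out lower numbers stand for higher toxicity in this test and higher numbers for lower toxicity in this test), compound 2 `CC(C)Oc1cc(C(=O)NCCCN(C)C)c2ccccc2n1` gives 122000 nM, the higher of the two numeric values in the series. Compound 1 `O=C(NC1CN2CCC1CC2)c1cc(-c2ccccc2)nc2ccccc12` gives a lower number, 46500 nM. Compound 3 `N=C(N)NC(=O)c1cc(-c2ccccc2)nc2ccccc12` reads > 250000 nM, which is a limit of the assay.

Compound 4 `CC(C)Oc1cc(C(=O)NC2CCN(C)CC2)c2ccccc2n1` differs from compound 2 as follows: 1-methylpiperidin-4-yl in place of 3-(dimethylamino)propyl on an amide-type nitrogen. Among the compounds with values here, the only measured step on an amide-type nitrogen is an at least 5.3-fold higher number from compound 1 to compound 3 (0.73 log units; beyond the scatter), which rests on that limit and belongs to a different core. Read in reverse, it offers weak support for a lower number when a ring enters, so no step beyond the scatter is expected in this assay, only a slight drift downward. The expected step is a 1.4-fold lower number from compound 2 to compound 4 (0.13 log units; within the scatter). For compound 4 the estimate is 90000 nM, with an expected range of 35000 nM to 230000 nM.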

Compound 4, half-maximal cytotoxic concentration: 101000 nM
Estimate against measurement, compound 4: 1.1-fold (0.05 log units) below; the range from low to high includes it.
By their numbers in this assay, from the lowest: compound 1; then compounds 4 and 2 (each within the scatter of the next). At a limit, above all of these: compound 3.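

On the shared core of this pair, in this assay, 1-methylpiperidin-4-yl in place of 3-(dimethylamino)propyl on an amide-type nitrogen gives a 1.2-fold lower number from compound 2 to compound 4 (0.08 log units; within the scatter). Unlike the earlier step at this place, which involved a different core, this pair gives a direct comparison of an open chain and a six-membered ring on one core, and the two do not separate. Nothing shown gives a cause for this step.

From the compounds shown here alone, whether a cyclohexyl group or a carboxylic acid on a longer chain would separate from these groups at this nitrogen remains open. So does whether the same exchange behaves alike on the core of compound 1.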